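A few compounds are considered here, and "the series" means these few. Any claim that something is new, unique, unknown or untested is made for them only; others in the source may bear on it.

Measured compounds:
compound 1 `CCN(CC)c1ccc2cc(C(=O)NC(C)C)c(=O)oc2c1` – 73000 nM
compound 2 `CCN(CC)c1ccc2cc(C(=O)NC3CC3)c(=O)oc2c1` – > 100000 nM

In a functional assay on HeLa cells (Homo sapiens) for cytotoxicity, read by MTT assay, with a stated time of 72 h (on this read-out higher numbers stand for weaker inhibition and lower numbers for stronger inhibition), compound 1 gives 73000 nM. Compound 2 is reported only as a limit of the assay, > 100000 nM. Among the measured compounds shown here, the one measured step, an at least 1.3-fold higher number from compound 1 to compound 2 (0.13 log units; that floor lies within the scatter), is therefore known only as a floor, since the value of compound 2 sits at the limit of > 100000 nM in this assay, at which 1 of the 2 values shown sits. Both numbers lie at the weak end of what the assay resolves.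

Compound 3 `CCN(CC)c1ccc2cc(C(=O)NO)c(=O)oc2c1` differs from compound 2 by
hydroxy in place of cyclopropyl on an amide-type nitrogen
The measured step swaps one small alkyl group for another on the same amide-type nitrogen and gives no guidance on a hydroxy entering there; it does show that both alkyl amides sit near or at the limit. For the measured compounds named here, with no measured step bearing on the change itself, the working expectation is a number in the same weak region, close to where compound 2 stands, with a considerable chance that compound 3 is again reported only as a limit. Compound 3 is thus estimated at 90000 nM, in a range of 25000 nM to 300000 nM, which means an expected step of an at least 1.1-fold lower number from compound 2 to compound 3 (0.04 log units; that floor lies within the scatter).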

Compound 3, half-maximal inhibitory concentration: 35900 nM
Beside the measured number, compound 3's estimate is 2.5-fold (0.40 log units) above it, within the range that was stated.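

In this assay, hydroxy in place of isopropyl on the amide-type nitrogen gives a 2.0-fold lower number from compound 1 to compound 3 (0.31 log units; beyond the scatter), so a change at this position can move the read-out beyond the scatter, which the floor of the step between the two alkyl amides could not show. Hydroxy in place of cyclopropyl gives an at least 2.7-fold lower number from compound 2 to compound 3 (0.44 log units; beyond the scatter), and this size is only a floor, with the true step possibly larger. The reading for compound 2 is a limit and not a number, which leaves the step from compound 1 as the only one of definite size among the hydroxy changes: the limit of > 100000 nM in this assay, at which 1 of the 3 values shown sits.

The compounds shown do not separate the entry of the hydroxy group, with its hydrogen-bond donor and acceptor, from the loss of the alkyl carbons, and a methoxy group on the same nitrogen would bear directly on that question. On these data alone, it also stays open how an unsubstituted amide, an amino group or a longer chain at this position would read, and whether any group there carries the number well clear of the weak end of the assay.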